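Nitro in Place of Trifluoromethyl on Two Related Cores

The source may report more compounds than this note shows. Statements on the series, on what has been measured and on what is new or still open speak of the compounds shown alone.

Four compounds are compared. Compound 1 `CC1(C)CC(C)(C)c2cc(NC(=O)Nc3ccc([N+](=O)[O-])cc3)ccc2O1` and compound 2 `CC1(C)CC(C)(C)c2cc(NC(=O)Nc3ccc(C(F)(F)F)cc3)ccc2O1` share one core, while compound 3 `CCC1(CC)CC(CC)(CC)c2cc(NC(=O)Nc3ccc(C(F)(F)F)cc3)ccc2O1` and compound 4 `CCC1(CC)CC(CC)(CC)c2cc(NC(=O)Nc3ccc([N+](=O)[O-])cc3)ccc2O1` share another. In a functional assay on A2780 cells (Homo sapiens) for inhibition, with a stated time of 72 h (on this read-out lower numbers stand for stronger inhibition and higher numbers for weaker inhibition), compound 1 gives 4100 nM, and compound 2 gives 3600 nM. Compound 1 differs from compound 2 by nitro in place of trifluoromethyl on an aromatic carbon and the step this produced was a 1.1-fold higher number from compound 2 to compound 1 (0.06 log units; within the scatter). Going by the values given here, compound 3 gives 2000 nM in this assay, the lowest of the three numbers so far, although its gap to compound 2 lies within the scatter and only its gap to compound 1 lies beyond it. How the core of compound 3 differs from the core of compound 2 is not broken down here.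

Compound 4 has not yet been measured. Among the compounds with values here, it differs from compound 3 by nitro in place of trifluoromethyl on an aromatic carbon, which is the same change, at the same kind of place, as the one made from compound 2 to compound 1. Because that earlier step was a 1.1-fold higher number from compound 2 to compound 1 (0.06 log units; within the scatter), a similarly small step is expected here, a 1.1-fold higher number from compound 3 to compound 4 (0.04 log units; within the scatter). This expectation rests on a single precedent, so the range around it is kept wide. Compound 4 is therefore estimated to give 2200 nM in this assay, expected to fall between 1000 nM and 4800 nM.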

Compound 4, half-maximal inhibitory concentration: 2090 nM
Estimate against measurement, compound 4: 1.1-fold (0.02 log units) above; the measured number falls inside the stated range.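

In this assay, placing nitro where trifluoromethyl stood on the core of compound 3 produced a 1.0-fold higher number from compound 3 to compound 4 (0.02 log units; within the scatter). Set beside the earlier step on the other core, the change carries from one core to the other with no difference that can be told apart in this read-out: the same change on two cores in this assay, a 1.1-fold higher number (0.06 log units; within the scatter) from compound 2 to compound 1 and a 1.0-fold higher number (0.02 log units; within the scatter) from compound 3 to compound 4, 1.1-fold (0.04 log units) apart, within the scatter of two such steps. Going by these compounds alone, this shows that, on these two cores and in this one cell read-out, the 4-(trifluoromethyl)phenyl to 4-nitrophenyl change leaves the number where it was, but it rests on only two pairs, both with steps within the scatter, so it shows agreement between two small steps and neither a general rule for other cores nor any reason why the two groups behave alike.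

The compounds shown leave open whether a nitrile, an amine or a carboxylic acid in the same place would also leave the number unchanged on both cores, or whether a plain hydrogen there would give a step of a different size. They also leave open whether the step would stay this small on a core carrying longer chains than those of compound 3 and compound 4.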